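Ethoxycarbonyl Enters the Outer Ring of Compound 2

This account rests on a few compounds, and the source may have more. Where it says the series, first, only, none or still open, it means among the compounds named here.

Three close relatives have been tested in an assay (Rattus norvegicus) for binding affinity to prostacyclin receptor (Homo sapiens), read by radioligand binding; a lower number here means a stronger inhibitor, a higher number a weaker inhibitor. Compound 1 `Clc1cccc(Cl)c1Sc1ccc(NC2=NCCN2)cc1` gives 631 nM, compound 2 `c1ccc(Sc2ccc(NC3=NCCN3)cc2)cc1` gives 794 nM, and compound 3 `COc1ccccc1Sc1ccc(NC2=NCCN2)cc1` gives 3980 nM. Among these three numbers compound 2 holds the second highest place; compound 1 sits nearest to it, with a gap inside the usual scatter of this assay, while compound 3 lies furthest away. For the measured compounds named here, the only single-point change among the measured pairs runs from compound 2 to compound 3, where a 5.0-fold higher number from compound 2 to compound 3 (0.70 log units; beyond the scatter) accompanies a methoxy group taking the place of a hydrogen on an aromatic carbon.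

Compound 4 `CCOC(=O)c1ccc(Sc2ccc(NC3=NCCN3)cc2)cc1` has not yet been measured. It differs from compound 2 in one place: ethoxycarbonyl in place of hydrogen on an aromatic carbon. Going by the values given here, the one measured step that bears on this change is the one from compound 2 to compound 3, in which a group entering on an aromatic carbon of the shared core raised the number modestly. Ethoxycarbonyl is a different group, and the data give no measured example of it, so that step is only a loose guide. The expected step is a 1.9-fold higher number from compound 2 to compound 4 (0.28 log units; within the scatter). Compound 4 is thus estimated at 1500 nM in this assay, with a range from 500 nM to 5000 nM.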

Compound 4, inhibition constant: 50.1 nM
For compound 4 the middle estimate is 30-fold (1.48 log units) above the measured one, outside the stated range (below it).
By their numbers in this assay, from the lowest: compound 4; then compounds 1 and 2 (each within the scatter of the next); then compound 3.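

In this assay, a 16-fold lower number from compound 2 to compound 4 (1.20 log units; beyond the scatter) shows that a group entering on an aromatic carbon of compound 2 can lower the number, and by a large margin. Set against a 5.0-fold higher number from compound 2 to compound 3 (0.70 log units; beyond the scatter), where methoxy enters, the two steps run in opposite directions, so among these compounds a new group on an aromatic carbon has no single direction of effect. Ethoxycarbonyl brings 5 heavy atoms, no ring and no net charge, and it sits para to a large group, but no measurement at hand explains why this change lowers the number.

A carboxylic acid, an amide or a longer ester chain at this same place would help show whether the drop in the number goes with the whole ethoxycarbonyl group or only with part of it, and the compounds shown cannot separate these possibilities. On these data alone, it also remains open how much of the contrast between methoxy and ethoxycarbonyl comes from the groups themselves and how much from where each one sits on its ring.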